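The compounds below may be only part of what the source reports. "The series", "measured", "known", "first", "only" and "open" are said of these compounds alone.

Compound 1 `CC(C)COc1cccc(-c2ccc(C(=O)N(Cc3cccc(OCCCCCC(=O)O)c3)C(C)C)cc2)c1` and compound 2 `CC(C)N(Cc1cccc(OCCCCCC(=O)O)c1)C(=O)c1ccc(-c2cccc(OC(F)(F)F)c2)cc1` share one core and differ only in the group on an oxygen on the outer aromatic ring. In an ADME assay on HepG2 cells (Homo sapiens) for cytotoxicity, read by CellTiter-Glo and resazurin assay, with a stated time of 72 h (on this read-out lower numbers stand for an effect already at smaller amounts and higher numbers for an effect only at larger amounts of compound), compound 1 gives > 26000 nM, which is a limit of the assay and not a number. In this assay compound 2 gives > 26000 nM, likewise a limit. The step that the two limits leave unreadable from compound 1 to compound 2 is therefore not readable, and compound 2 stands at the limit of > 26000 nM in this assay, at which 2 of the 2 values shown sit, together with compound 1.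

Compound 3 `COc1ccc(F)c(-c2ccc(C(=O)N(Cc3cccc(OCCCCCC(=O)O)c3)C(C)C)cc2)c1` has not yet been measured in this assay. It differs from compound 2 by 2-fluoro-5-methoxyphenyl in place of 3-(trifluoromethoxy)phenyl on an aromatic carbon. Within the data shown here, the only measured step that bears on this position, a step that the two limits leave unreadable from compound 1 to compound 2, gives no size because both of its ends sit at the limit of > 26000 nM in this assay, at which 2 of the 2 values shown sit. The evidence thus offers no sign of an effect in this assay for either compound already measured, and no step beyond the scatter is expected from compound 2 to compound 3.

Compound 3 is accordingly expected to give about 30000 nM in this assay, within 15000 nM to 60000 nM. The step this estimate implies, a step that the limit leaves unreadable from compound 2 to compound 3, is expected to be negligible, with a further limit the most likely outcome.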

Compound 3, half-maximal effective concentration: > 26000 nM
Compound 3 ended at the assay's limit; the forecaster's own chance of this, stated with the estimate: 85%; the middle value is on the limit's open side.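

In this assay compound 3 gives > 26000 nM, which is a limit of the assay and not a number. The steps from compound 1 and from compound 2 to compound 3 therefore cannot be read, and all three compounds stand together: the limit of > 26000 nM in this assay, at which 3 of the 3 values shown sit.

The compounds shown leave open at what concentration, if any, an effect would appear in this assay, and whether the group on the outer aromatic ring changes it.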